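Shortening the ester chain of compound 1

The source may report more compounds than this note shows. Statements on the series, on what has been measured and on what is new or still open speak of the compounds shown alone.

Measured so far:
compound 1 `CCCOC(=O)/C=C/c1ccc(C(C)C)cc1` — 8%
compound 2 `CC(C)c1ccc(/C=C/C(=O)OCCOc2ccccc2)cc1` — 32%

In a functional assay on the whole organism for inhibition, with Brassica rapa subsp. chinensis as the target, with a stated time of 3 days, tested at 100 ppm (on this read-out higher numbers stand for more inhibition of growth at the one concentration tested and lower numbers for less inhibition of growth), compound 1 gives 8%, the lowest of the two numbers shown; its nearest neighbour is compound 2, which gives 32%. Compound 3 `COC(=O)/C=C/c1ccc(C(C)C)cc1` differs from compound 1 by hydrogen in place of ethyl on a saturated chain carbon bound to an oxygen next to a carbonyl group. Within the data shown here, the only measured step, a number 24 percentage points higher from compound 1 to compound 2 (beyond the scatter), changes the far end of the ester chain, not the chain length, so it offers no direct guide here. Among the measured compounds shown here, with no measured step on the chain itself, no change beyond the scatter is expected, and compound 3 is estimated at 10% (range 0% to 30%), a step of a number 2 percentage points higher from compound 1 to compound 3 (within the scatter).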

Compound 3, percent growth inhibition at one concentration: 38%
Estimate against measurement, compound 3: 28 percentage points below, outside the stated range (above it).
By their numbers in this assay, from the lowest: compound 1; then compounds 2 and 3 (each within the scatter of the next).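

In this assay the ester chain gives a number 30 percentage points higher from compound 1 to compound 3 (beyond the scatter) on going from propyl to methyl. This position therefore responds to chain length itself, which compound 2 could not show, as its change lay at the far end of the chain. No available data account for this step.

On these data alone, the ethyl ester, a longer chain such as butyl and the free carboxylic acid remain open. Whether the response runs steadily with chain length or is confined to the methyl ester cannot be told from these compounds.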